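The compounds below may be only part of what the source reports. "The series", "measured", "known", "first", "only" and "open" are said of these compounds alone.

Among the measured compounds shown here, compound 2 `CN(C)c1ccc(NC(=O)Nc2cccc(CNc3nccnc3Cl)c2)cc1` gives 11500 nM in a functional assay on MGC-803 cells (Homo sapiens) for antiproliferative activity, read by MTT assay, with a stated time of 48 h (on this read-out higher numbers stand for weaker inhibition and lower numbers for stronger inhibition), and this lies within the scatter of the only other measured compound, compound 1 `Cc1ccc(NC(=O)Nc2cccc(CNc3nccnc3Cl)c2)cc1`, which gives 11900 nM. Compound 3 `Cc1cccc(NC(=O)Nc2cccc(CNc3nccnc3Cl)c2)c1` differs from compound 2 by 3-methylphenyl in place of 4-(dimethylamino)phenyl on an amide-type nitrogen. For the measured compounds named here, the one measured step, a 1.0-fold lower number from compound 1 to compound 2 (0.01 log units; within the scatter), also swapped a substituent on this ring and stayed within the scatter, so for compound 3 a step of about a 1.0-fold higher number from compound 2 to compound 3 (0.02 log units; within the scatter) is expected, with no change beyond the scatter. Compound 3 is therefore estimated at 12000 nM, with a range from 6000 nM to 25000 nM.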

Compound 3, half-maximal inhibitory concentration: 14600 nM
Compound 3: middle estimate off by 1.2-fold (0.09 log units), on the low side; measured number inside the range.
By their numbers in this assay, from the lowest: compounds 2, 1 and 3 (each within the scatter of the next).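

The 3-methylphenyl group on this amide-type nitrogen stands in for 4-methylphenyl (a 1.2-fold higher number from compound 1 to compound 3 (0.09 log units; within the scatter)) and for 4-(dimethylamino)phenyl (a 1.3-fold higher number from compound 2 to compound 3 (0.10 log units; within the scatter)). So in this assay neither moving the methyl group around the ring nor replacing the dimethylamino-bearing ring separates these three compounds. No evidence is available on what lies behind this.

Going by these compounds, it remains open whether a different kind of group on this ring, such as a carboxylic acid, a primary amine or a chlorine atom, would shift the number beyond the scatter. Replacing the ring with a longer alkyl chain is equally untested here.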